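Carbamate for amide: lipophilicity outlook for compound 4

A few compounds are considered here, and "the series" means these few. Any claim that something is new, unique, unknown or untested is made for them only; others in the source may bear on it.

In a physicochemical assay for lipophilicity, at pH 7.4 (a higher number here means a more lipophilic compound, a lower number a more polar compound), compound 1 `Cc1cc(C(=O)O)nn1Cc1cc(Br)ccc1OCc1ccccc1` gives 1.2. Compound 2 `Cc1cc(C(=O)NCc2ccncc2)nn1Cc1cc(Cl)ccc1OCc1ccccc1` returns only a limit of the assay, > 3.7. Compound 3 `Cc1cc(NC(=O)C2CCCCC2)nn1Cc1cc(Cl)ccc1OCC(C)C` likewise returns a limit, > 3.7. Among the three measured values, compound 2 therefore stands at the limit of > 3.7 in this assay, at which 2 of the 3 values shown sit, with no number of its own. Within the data shown here, no two measured compounds differ in a single place, so no measured step is available to guide the next change. Compound 4 `Cc1cc(NC(=O)OCc2ccccn2)nn1Cc1cc(Cl)ccc1OCc1ccccc1` differs from compound 2 by (((pyridin-2-yl)methoxy)carbonyl)amino in place of ((pyridin-4-yl)methyl)carbamoyl on an aromatic carbon. The step from compound 2 to compound 4 is expected to be small, a step that the limit leaves unreadable from compound 2 to compound 4, within or close to the scatter. For compound 4 the expected value in this assay is 3.8, between 3.3 and 4.3.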

Compound 4, distribution coefficient: 3.1
For compound 4 the middle estimate is 0.70 log units above the measured one; measured number outside the range, below it.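

In this assay, the series now has its first readable change in one place: (((pyridin-2-yl)methoxy)carbonyl)amino in place of ((pyridin-4-yl)methyl)carbamoyl on this aromatic carbon gives a number at least 0.60 log units lower from compound 2 to compound 4 (beyond the scatter). Compound 4 gives 3.1, so a change at this position alone, with the rest of the molecule held, brings a measured number. Compound 2 has only a limit, so the size of this step remains a bound: the limit of > 3.7 in this assay, at which 2 of the 4 values shown sit.

This one pair cannot separate the effect of the linking atoms from that of pyridin-2-yl against pyridin-4-yl. As far as these compounds go, the reading at this position for a primary amine or a sulfonamide also remains open.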